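A Methoxyphenyl Amide Measured Against Its Aminophenyl Relative

This account rests on a few compounds, and the source may have more. Where it says the series, first, only, none or still open, it means among the compounds named here.

Three amides on a shared core have been measured in an assay (strain Wistar) for displacement of a labelled ligand from adenosine receptor A1 (Rattus norvegicus), read by scintillation counting; a higher number here means a weaker inhibitor, a lower number a stronger inhibitor. Compound 1 `CCOc1ccccc1C(=O)Nc1nc(-c2ccccc2)nc2c1nnn2Cc1ccccc1` gives 1850 nM, compound 2 `O=C(Nc1nc(-c2ccccc2)nc2c1nnn2Cc1ccccc1)c1cccc([N+](=O)[O-])c1` gives 77 nM, and compound 3 `Nc1ccc(C(=O)Nc2nc(-c3ccccc3)nc3c2nnn3Cc2ccccc2)cc1` gives 7.1 nM, the lowest of the three numbers. The steps are a 24-fold lower number from compound 1 to compound 2 (1.38 log units; beyond the scatter), a 260-fold lower number from compound 1 to compound 3 (2.42 log units; beyond the scatter) and an 11-fold lower number from compound 2 to compound 3 (1.04 log units; beyond the scatter), all beyond the scatter.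

Compound 4 `COc1ccccc1C(=O)Nc1nc(-c2ccccc2)nc2c1nnn2Cc1ccccc1` differs from compound 3 by one change: 2-methoxyphenyl in place of 4-aminophenyl on a carbonyl carbon. The step that bears most directly on it is a 260-fold lower number from compound 1 to compound 3 (2.42 log units; beyond the scatter), since compound 1 carries a 2-ethoxyphenyl on the same carbonyl carbon and 2-methoxyphenyl differs from it only in the length of the alkoxy chain. The step from compound 3 to compound 4 runs that change in reverse, so a large upward step in this assay is expected, roughly a 210-fold higher number from compound 3 to compound 4 (2.32 log units; beyond the scatter). Compound 4 is therefore estimated at 1500 nM, within a range from 400 nM to 6000 nM.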

Compound 4, inhibition constant: 1520 nM
The estimate for compound 4 lay 1.0-fold (0.01 log units) below the measured number; the range from low to high includes it.
By their numbers in this assay, from the lowest: compound 3; then compound 2; then compounds 4 and 1 (each within the scatter of the next).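

Shortening the alkoxy chain from 2-ethoxyphenyl to 2-methoxyphenyl on the carbonyl carbon leaves the reading in this assay unchanged within the scatter (a 1.2-fold lower number from compound 1 to compound 4 (0.09 log units; within the scatter)), so at this position the two chain lengths cannot be told apart. The large gaps to the other amides also hold for the shorter chain (a 210-fold higher number from compound 3 to compound 4 (2.33 log units; beyond the scatter); a 20-fold higher number from compound 2 to compound 4 (1.30 log units; beyond the scatter)), which means the high number is not confined to the 2-ethoxyphenyl amide. Nothing available explains the size of these steps.

Since 2-methoxyphenyl and 4-aminophenyl differ both in the group they carry and in where it sits on the ring, the compounds shown leave open which of the two carries the large step. They also leave open how a plain phenyl, a longer alkoxy chain or an amine in place of the methoxy would read.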